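Cytotoxicity notes: aryl swap on the pyrazole nitrogen

A few compounds are considered here, and "the series" means these few. Any claim that something is new, unique, unknown or untested is made for them only; others in the source may bear on it.

Measured so far in an ADME assay on Huh-7 cells (Homo sapiens) for cytotoxicity; on this read-out lower numbers stand for higher toxicity in this test and higher numbers for lower toxicity in this test:
- compound 1 `CN1CCN(CCNCc2cn(-c3ccc(F)cc3F)nc2-c2ccc(Cl)cc2)CC1`: 19000 nM
- compound 2 `Cc1ccccc1-c1nn(-c2ccc(F)cc2F)cc1CNCCN(C)C`: > 20000 nM, a limit of this assay the limit of > 20000 nM in this assay, at which 1 of the 3 values shown sits.
- compound 3 `Cc1ccccc1-c1nn(-c2ccc(Cl)cc2)cc1CNCCN1CCN(C)CC1`: 17000 nM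

Compound 3 gives the lowest of the two numbers in this assay; compound 1 sits within the scatter of it, and the value of compound 2 is a limit only. Compound 4 `Cc1ccccc1-c1nn(-c2ccc(F)cc2F)cc1CNCCN1CCN(C)CC1` is the next step from compound 3: 2,4-difluorophenyl in place of 4-chlorophenyl on an aromatic nitrogen. Within the data shown here, no measured pair in this set isolates this change, so the step is expected to be small and in no particular direction: a 1.1-fold higher number from compound 3 to compound 4 (0.05 log units; within the scatter). Compound 1, which carries the same 2,4-difluorophenyl group, gives 19000 nM, which supports an estimate for compound 4 of 19000 nM, between 10000 nM and 40000 nM. For compound 4 there is a fair chance that only a limit of this assay is reported.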

Compound 4, half-maximal cytotoxic concentration: > 20000 nM
Compound 4: no number, only a limit (the forecaster's own chance of this, stated with the estimate: 40%); middle value at least 1.0-fold (0.02 log units) away from the limit.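

Among these compounds, with 2,4-difluorophenyl in place of 4-chlorophenyl on the aromatic nitrogen, this assay gives an at least 1.1-fold higher number from compound 3 to compound 4 (0.07 log units; that floor lies within the scatter), the first direct reading of this change at this position. With 2-methylphenyl in place of 4-chlorophenyl on the aromatic carbon, the same read-out gives an at least 1.0-fold higher number from compound 1 to compound 4 (0.02 log units; that floor lies within the scatter). Compound 4 gives a limit, not a number, as does compound 2: the limit of > 20000 nM in this assay, at which 2 of the 4 values shown sit.

As far as these compounds go, the step between these two compounds cannot be read, so the exchange of dimethylamino for 4-methylpiperazin-1-yl stays open. Also open, from the compounds shown here alone, is whether a 4-methoxyphenyl group on the aromatic nitrogen would give a number in this read-out.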